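A few compounds are considered here, and "the series" means these few. Any claim that something is new, unique, unknown or untested is made for them only; others in the source may bear on it.

Measured so far in a toxicity assay on the whole organism with Rattus norvegicus as the target, at a dose of 200 mg/kg by the oral route; on this read-out lower numbers stand for a weaker effect and higher numbers for a stronger effect at the one dose given:
- compound 1 `COc1ccc(OCC2=NCCO2)cc1`: 70%
- compound 2 `Clc1ccc(OCC2=NCCO2)cc1`: 60%

Compound 2 carries the lower of the two numbers on paper, yet the step of a number 10 percentage points lower from compound 1 to compound 2 (within the scatter) lies within the scatter, so the two compounds are not separated in this assay.

Compound 3 `Brc1ccc(OCC2=NCCO2)cc1` differs from compound 2 in one place: bromo in place of chloro on an aromatic carbon. Within the data shown here, the only step measured, from compound 1 to compound 2, swaps a methoxy for a chloro and stays within the scatter; no step from one halogen to another has been measured. Compound 3 is therefore expected to show no step beyond the scatter, no change at the digits printed from compound 2 to compound 3 (within the scatter). Compound 3 is estimated at 60%, with a range from 45% to 75%.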

Compound 3, a percentage reported as activity, at one dose (the size of the read-out at that dose, not a potency): 80%
Beside the measured number, compound 3's estimate is 20 percentage points below it; measured number outside the range, above it.
By their numbers in this assay, from the lowest: compounds 2, 1 and 3 (each within the scatter of the next, the first and the last beyond it).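

In this assay, among these compounds, bromo in place of chloro on this aromatic carbon gives the first step beyond the scatter (a number 20 percentage points higher from compound 2 to compound 3 (beyond the scatter)), so this position responds to a swap of one halogen for another. Bromo in place of methoxy gives no such separation (a number 10 percentage points higher from compound 1 to compound 3 (within the scatter)). Only the two halogens are therefore told apart here, while methoxy stays within the scatter of each.

From the compounds shown here alone, how a fluoro group, an amine or a carboxylic acid on this aromatic carbon would read stays open. Nothing at hand bears on what lies behind the step between the two halogens.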